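Bringing a chloro back to the aryl ring of compound 3

A few compounds are considered here, and "the series" means these few. Any claim that something is new, unique, unknown or untested is made for them only; others in the source may bear on it.

All four compounds share one core. Compound 1 `O=C(CCN1CCN(c2ccnc3cc(Cl)ccc23)CC1)N/N=C/c1ccc(Cl)cc1` gives 200 nM in an ADME assay on cells (Splenocyte, Mus musculus, strain BALB/c) for cytotoxicity, read by thymidine incorporation, with a stated time of 24 h; a lower number here means a stronger inhibitor, a higher number a weaker inhibitor. Compound 2 `COc1cc(/C=N/NC(=O)CCN2CCN(c3ccnc4cc(Cl)ccc34)CC2)c(Br)c(OC)c1OC` gives 9600 nM in this assay. Compound 3 `CN(C)c1ccc(/C=N/NC(=O)CCN2CCN(c3ccnc4cc(Cl)ccc34)CC2)cc1` reaches only a limit of this assay, > 100000 nM. Among the three numbers shown, compound 3 therefore stands at the weak end. For the measured compounds named here, the single measured step that touches it is an at least 500-fold higher number from compound 1 to compound 3 (2.69 log units; beyond the scatter), and since it ends at the limit of > 100000 nM in this assay, at which 1 of the 3 values shown sits, its true size is known only as a lower bound.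

Compound 4 `O=C(CCN1CCN(c2ccnc3cc(Cl)ccc23)CC1)N/N=C/c1cccc(Cl)c1` has not yet been measured. It differs from compound 3 by 3-chlorophenyl in place of 4-(dimethylamino)phenyl on a carbon with a double bond to nitrogen. Going by the values given here, the 3-chlorophenyl of compound 4 is not the 4-chlorophenyl of compound 1, so the reversal is not exact, but the only step available runs from compound 1 to compound 3 and is large. Its reversal points to a large fall in the number, tempered by the changed chlorophenyl. Compound 4 is thus expected at 500 nM, within a range from 100 nM to 5000 nM. That corresponds to an expected step of an at least 200-fold lower number from compound 3 to compound 4 (2.30 log units; beyond the scatter).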

Compound 4, half-maximal inhibitory concentration: > 100000 nM
Compound 4 was reported as a limit (the forecaster's own chance of this, stated with the estimate: 5%); middle value at least 200-fold (2.30 log units) from the limit.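

In this assay compound 4 gives > 100000 nM, which is a limit of the assay and not a number. With 3-chlorophenyl in place of 4-chlorophenyl on this carbon, the data show an at least 500-fold higher number from compound 1 to compound 4 (2.69 log units; beyond the scatter), so a chloro on the aryl ring does not by itself carry the low number of compound 1, and a change in the chlorophenyl alone is enough for a large step. Compound 3 and compound 4 now stand at the same limit, and the step between them cannot be read: the limit of > 100000 nM in this assay, at which 2 of the 4 values shown sit.

As far as these compounds go, how far compound 3 and compound 4 really lie past that limit stays unknown. Also open, from the compounds shown here alone, is whether a fluoro or a nitrile in place of the chloro of compound 1 would keep a low number.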